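One Aromatic Ring Exchanged on a Shared Core

The source may hold more compounds than are shown below. What is called first, only, known or untested is meant among the compounds shown, and "the series" means these compounds.

compound 1 `COc1cc(C2=C(c3cc(C)c(OC)c(C)c3)C(O)CC2=O)cc(OC)c1OC` — > 100 ug/mL
compound 2 `COc1ccc(C2=C(c3cc(OC)c(OC)c(OC)c3)C(=O)CC2OC(C)=O)cc1NC=O` — "not determined" (no result reported)

In an ADME assay on ECV-304 cells (Homo sapiens) for cytotoxicity, read by MTT assay, with a stated time of 72 h (on this read-out higher numbers stand for weaker inhibition and lower numbers for stronger inhibition), compound 1 gives > 100 ug/mL, which is a limit of the assay rather than a number. Compound 2 has no result in this assay, so it stands nowhere on the numbers shown; the only reference point is the limit of > 100 ug/mL in this assay, at which 1 of the 2 values shown sits. Compound 3 `COc1cc(C2=C(c3cc(C)c(OC)c(C)c3)C(OC(C)=O)CC2=O)cc(OC)c1OC` arises from compound 2 by 4-methoxy-3,5-dimethylphenyl in place of 3-(formylamino)-4-methoxyphenyl on a double-bonded ring carbon. Within the data shown here, no measured step supports sizing this change, so no shift beyond the scatter is expected in this assay. Compound 3 is expected to give about 100 ug/mL (from 40 ug/mL to 200 ug/mL), most likely reported once more as a limit.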

Compound 3, half-maximal inhibitory concentration: > 100 ug/mL
Compound 3 was reported as a limit; the forecaster's own chance of this, stated with the estimate: 75%; the middle value sits exactly at the limit.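

Compound 1 and compound 3 both stop at a limit of the assay, so the step between them, acetyl in place of hydrogen on an oxygen, cannot be read. The compounds shown leave open how compound 2 compares, and whether any change on the shared core gives a number instead of a limit.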